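Exchanging Bromo for Chloro on a Fused Aromatic Ring

The compounds below may be only part of what the source reports. "The series", "measured", "known", "first", "only" and "open" are said of these compounds alone.

Compound 3 `Cc1cc(S(N)(=O)=O)ccc1NC(=O)COc1ccc(F)cc1Oc1ccc2cc(C#N)ccc2c1Br` was tested in an ADME assay on C8166 cells (Homo sapiens) for cytotoxicity, read by MTT assay (a lower number here means that less compound is tolerated, a higher number that more compound is tolerated), where compound 3 gives 35300 nM. Among the three measured compounds this is the lowest number, but compound 1 `Cc1cc(S(N)(=O)=O)ccc1NC(=O)COc1ccc(F)cc1Oc1ccc2ccccc2c1Cl` stands close to it, since compound 1 gives 47100 nM, and the gap between them is within the usual scatter. Compound 2 `Cc1cc(S(N)(=O)=O)ccc1NC(=O)COc1ccc(F)cc1Oc1ccc2cc(Br)ccc2c1Cl` lies furthest away, as compound 2 gives 195000 nM. Among the measured compounds shown here, the only single-point step measured so far, a 4.1-fold higher number from compound 1 to compound 2 (0.62 log units; beyond the scatter), concerns a different position and a different kind of change, bromo entering for hydrogen rather than one halogen replacing another.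

Compound 4 `Cc1cc(S(N)(=O)=O)ccc1NC(=O)COc1ccc(F)cc1Oc1ccc2cc(C#N)ccc2c1Cl` differs from compound 3 by chloro in place of bromo on an aromatic carbon. For the measured compounds named here, no measured step bears directly on a bromo-to-chloro exchange, and the one step available is modest in size, so no change beyond the scatter is expected here. The estimated step of a 1.1-fold higher number from compound 3 to compound 4 (0.05 log units; within the scatter) is therefore small. For compound 4 in this assay the expected value is 40000 nM, with a range from 18000 nM to 90000 nM.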

Compound 4, half-maximal cytotoxic concentration: 39700 nM
Compound 4: middle estimate off by 1.0-fold (0.00 log units), on the high side; low and high end bracket the measured number.
By their numbers in this assay, from the lowest: compounds 3, 4 and 1 (each within the scatter of the next); then compound 2.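

In this assay, among the compounds shown here, the exchange of bromo for chloro on this aromatic carbon, ortho to a fused ring, stays within the scatter with a cyano group present elsewhere on the fused system (a 1.1-fold higher number from compound 3 to compound 4 (0.05 log units; within the scatter)), the first direct reading of a halogen exchange at this place. At the carbon carrying that cyano group, the new compound also shows that cyano and hydrogen cannot be told apart (a 1.2-fold lower number from compound 1 to compound 4 (0.07 log units; within the scatter)), while cyano and bromo can (a 4.9-fold lower number from compound 2 to compound 4 (0.69 log units; beyond the scatter)), so among these three groups only bromo goes with the higher number there. No available evidence explains either finding.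

On these data alone, whether the halogen exchange would stay as small with bromo or hydrogen in place of the cyano group remains open. So does the outcome of placing an amine or a carboxylic acid on the halogen-bearing carbon.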